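Removing a Phenolic Hydroxy Group on a Biaryl Aldehyde Core

This account rests on a few compounds, and the source may have more. Where it says the series, first, only, none or still open, it means among the compounds named here.

Measured compounds:
compound 1, `COc1cc(-c2c(C=O)c(O)cc3cc(OC)c(O)cc23)ccc1O`, 130 nM
compound 2, `COc1cc(-c2cc(C=O)cc3cc(OC)c(O)cc23)ccc1O`, 500 nM
compound 3, `COc1cc(-c2cc(C=O)c(O)c3cc(OC)c(O)cc23)ccc1O`, 150 nM

The three measured compounds were tested in a functional assay on RAW264.7 cells (Mus musculus) for inhibition, read by Griess assay, with a stated time of 24 h; on this read-out lower numbers stand for stronger inhibition and higher numbers for weaker inhibition. Compound 1 gives the lowest of the three numbers, and compound 3 sits within the usual scatter of it; compound 1 and compound 3 have the same atoms joined differently, and the difference between their two cores is not broken down here. Among the compounds with values here, the one measured single-point step is a 3.3-fold higher number from compound 3 to compound 2 (0.52 log units; beyond the scatter), the change being (hydrogen in place of hydroxy on an aromatic carbon).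

Compound 4, `COc1cc(-c2c(C=O)ccc3cc(OC)c(O)cc23)ccc1O`, has not yet been measured. It differs from compound 1 by hydrogen in place of hydroxy on an aromatic carbon, the same kind of change as that from compound 3 to compound 2, although the surroundings differ: in compound 3 the hydroxy stands ortho to a fused ring and para to a group of 9 heavy atoms, whereas in compound 1 it stands meta and para to fused rings and meta to a group of 9 heavy atoms. Resting on that earlier step, compound 4 is expected to show a 3.1-fold higher number from compound 1 to compound 4 (0.49 log units; beyond the scatter) in this assay. Compound 4 is therefore estimated at 400 nM, within 150 nM to 1000 nM.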

Compound 4, half-maximal inhibitory concentration: 570 nM
The estimate for compound 4 lay 1.4-fold (0.15 log units) below the measured number; the measured number falls inside the stated range.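

On a second core, hydrogen in place of hydroxy on an aromatic carbon gave a 4.4-fold higher number from compound 1 to compound 4 (0.64 log units; beyond the scatter) in this assay. The change thus carried over between the two cores shown, and the sizes of the two steps cannot be told apart: the same change on two cores in this assay, a 3.3-fold higher number (0.52 log units; beyond the scatter) from compound 3 to compound 2 and a 4.4-fold higher number (0.64 log units; beyond the scatter) from compound 1 to compound 4, 1.3-fold (0.12 log units) apart, within the scatter of two such steps. Within the data shown here, this rests on only two pairs of compounds, with the hydroxy group in different surroundings in each; it shows that the same replacement gave weaker inhibition on both cores, but not that it would do so on any further core, and it does not explain why the hydroxy group matters.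

The compounds shown leave open whether an amine in place of this hydroxy group would keep the lower numbers, since hydrogen is the only replacement on view. They also leave open how the step would behave if a carboxylic acid stood in place of the formyl group.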